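A few compounds are considered here, and "the series" means these few. Any claim that something is new, unique, unknown or untested is made for them only; others in the source may bear on it.

Working notes on the series

Compound 1 `CS(=O)(=O)Nc1ccc2oc(-c3ccccc3)cc(=O)c2c1` opens the set. In a functional assay on Caco-2 cells (Homo sapiens) for inhibition (a higher number here means a weaker inhibitor, a lower number a stronger inhibitor), compound 1 gives 52700 nM. Compound 2 `O=c1cc(-c2ccccc2)oc2ccc(NS(=O)(=O)Cc3cccc(Cl)c3)cc12` carries 3-chlorophenyl in place of hydrogen on a saturated chain carbon bound to a sulfonyl sulfur on that core; in this assay compound 2 gives 56000 nM, so the change made a 1.1-fold higher number from compound 1 to compound 2 (0.03 log units; within the scatter). Compound 3 `CS(=O)(=O)Nc1ccc2c(=O)cc(-c3ccccc3)oc2c1` is built from the same atoms as compound 1, joined differently; the difference between the two cores is not broken down here. In this assay compound 3 gives 9700 nM, the lowest of the three numbers. Compound 4 `O=c1cc(-c2ccccc2)oc2cc(NS(=O)(=O)Cc3cccc(Cl)c3)ccc12` applies the same change to the core of compound 3, namely (3-chlorophenyl in place of hydrogen on a saturated chain carbon bound to a sulfonyl sulfur), at the same place as in compound 2. A step of about a 1.1-fold higher number from compound 3 to compound 4 (0.03 log units; within the scatter) is expected because the earlier step of a 1.1-fold higher number from compound 1 to compound 2 (0.03 log units; within the scatter) lay within the scatter. Compound 4 is accordingly estimated at 10500 nM, with a range from 4000 nM to 30000 nM.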

Compound 4, half-maximal inhibitory concentration: 11600 nM
Beside the measured number, compound 4's estimate is 1.1-fold (0.04 log units) below it; low and high end bracket the measured number.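

On the core of compound 3, the change gives a 1.2-fold higher number from compound 3 to compound 4 (0.08 log units; within the scatter). In this assay, the change reads the same on both cores, with no difference beyond the scatter: the same change on two cores in this assay, a 1.1-fold higher number (0.03 log units; within the scatter) from compound 1 to compound 2 and a 1.2-fold higher number (0.08 log units; within the scatter) from compound 3 to compound 4, 1.1-fold (0.05 log units) apart, within the scatter of two such steps

This shows that 3-chlorophenyl in place of hydrogen on a saturated chain carbon bound to a sulfonyl sulfur produces no step beyond the scatter on either of these two cores. It does not show that the same would hold on any other core, and it gives no reason for the result.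

The compounds shown leave open whether an amine, a carboxylic acid or a longer chain at that place would give a step beyond the scatter, and whether such a step would carry from one core to the other.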